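Amide substituent variation in the shared series

The source may report more compounds than this note shows. Statements on the series, on what has been measured and on what is new or still open speak of the compounds shown alone.

Compound 2 `CC(C)NC(=O)/C=C1\CCc2ccc(F)cc21` stands highest of the two numbers obtained so far, giving 100% in a functional assay on the whole organism with Mus musculus as the target, at a dose of 100 mg/kg by the intraperitoneal route; a lower number here means less inhibition, a higher number more inhibition at the dose given (going by the name of the read-out); compound 1 `O=C(/C=C1\CCc2ccc(F)cc21)NCC1CC1` gives 50% in this assay. Among the compounds with values here, the single measured step, a number 50 percentage points higher from compound 1 to compound 2 (beyond the scatter), shows that a change at the amide-type nitrogen alone can move the read-out strongly. Compound 3 `O=C(/C=C1\CCc2ccc(F)cc21)N1CCCC1` carries pyrrolidin-1-yl in place of isopropylamino on a carbonyl carbon. Within the data shown here, no measured step removes the hydrogen-bond donor or introduces a ring at this place, so the direction is open, and compound 2 already sits at the top of the scale. The expected step is a number 35 percentage points lower from compound 2 to compound 3 (beyond the scatter). Compound 3 is therefore estimated at 65%, with a range from 25% to 100%.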

Compound 3, a percentage reported as inhibition, in the whole organism at one dose (the size of the read-out at that dose, not a potency): 33%
Compound 3: the middle estimate sits 32 percentage points above what was measured; the measured number falls inside the stated range.
By their numbers in this assay, from the lowest: compound 3; then compound 1; then compound 2.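

At the carbonyl carbon, pyrrolidin-1-yl gives a number 67 percentage points lower from compound 2 to compound 3 (beyond the scatter) in this assay and a number 17 percentage points lower from compound 1 to compound 3 (beyond the scatter) as well, placing it below both isopropylamino and (cyclopropylmethyl)amino. This change removes the hydrogen-bond donor of isopropylamino and adds a five-membered ring on the nitrogen together, so the compounds shown cannot separate the two. Nothing available explains the drop. Open, as far as these compounds go, is whether dimethylamino, with no donor and no ring, falls as far. Also open, from the compounds shown here alone, is whether tert-butylamino or cyclobutylamino, each keeping the amide hydrogen, holds the read-out of compound 2.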